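The compounds below may be only part of what the source reports. "The series", "measured", "known", "first", "only" and "open" are said of these compounds alone.

In an ADME assay on isolated protein for inhibition of Dipeptidyl peptidase 9 (Homo sapiens), with stated times of 15 min, 60 s and 20 min (on this read-out higher numbers stand for weaker inhibition and lower numbers for stronger inhibition), compound 1 `CC#CCn1c(N2CCC[C@@H](N)C2)nc2c1c(=O)n(Cc1c(Br)cccc1C(=O)O)c(=O)n2C` gives > 100000 nM, which is a limit of the assay rather than a number.
In this assay compound 2 `CC#CCn1c(N2CCC[C@@H](N)C2)nc2c1c(=O)n(Cc1ccc(Br)cc1C(=O)OC)c(=O)n2C` gives > 100000 nM, likewise a limit of the assay.

Compound 1 therefore stands only at a limit: both values shown sit at the limit of > 100000 nM in this assay, at which 2 of the 2 values shown sit. Among the compounds with values here, the single recorded step, a step that the two limits leave unreadable from compound 1 to compound 2, is left unreadable by the two limits.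

Compound 3 `CC#CCn1c(N2CCC[C@@H](N)C2)nc2c1c(=O)n(Cc1ccc(Br)cc1C(=O)O)c(=O)n2C` differs from compound 1 by 4-bromo-2-carboxyphenyl in place of 2-bromo-6-carboxyphenyl on a saturated chain carbon bound to an aromatic nitrogen. No measured step bears readably on this change, and nothing shown separates the two measured compounds from each other. Compound 3 is expected to stay at the limit as well, so the expected step that the limit leaves unreadable from compound 1 to compound 3 is none beyond the scatter in either direction. The estimate for compound 3 in this assay is 200000 nM, with a range from 30000 nM to 1000000 nM.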

Compound 3, half-maximal inhibitory concentration: > 100000 nM
Compound 3 was reported as a limit (the forecaster's own chance of this, stated with the estimate: 85%); the middle value lies beyond the limit too.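

Compound 3, like compound 1 and compound 2, is reported only as a limit in this assay, so no step among these three compounds can be read: the limit of > 100000 nM in this assay, at which 3 of the 3 values shown sit.

The compounds shown leave open whether the 2-bromo-6-carboxybenzyl and 4-bromo-2-carboxybenzyl groups differ at all on this read-out.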